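The source may hold more compounds than are shown below. What is called first, only, known or untested is meant among the compounds shown, and "the series" means these compounds.

Compound 3, with the structure `Nc1ccc(-c2cc(=O)c3c(N)c(F)c(Cl)c(F)c3o2)cc1F`, gives 210 nM in a functional assay on MCF7 cells (Homo sapiens) for cytotoxicity, read by neutral red uptake, with a stated time of 3 days (a higher number here means a weaker inhibitor, a lower number a stronger inhibitor), the highest of the two plain numbers in this set. Compound 1, `Nc1ccc(-c2cc(=O)c3c(N)c(F)cc(F)c3o2)cc1F`, gives 40 nM in this assay, and the step of a 5.3-fold higher number from compound 1 to compound 3 (0.72 log units; beyond the scatter) is a modest weakening. Compound 2, `Nc1ccc(-c2cc(=O)c3c(N)c(F)c(O)c(F)c3o2)cc1F`, reaches only the limit of this assay, > 10000 nM, which is a bound rather than a number; this is the limit of > 10000 nM in this assay, at which 1 of the 3 values shown sits. The step of an at least 250-fold higher number from compound 1 to compound 2 (2.39 log units; beyond the scatter) is large, and so is the step of an at least 47-fold lower number from compound 2 to compound 3 (1.67 log units; beyond the scatter), with compound 3 on the stronger side.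

The next compound, compound 4, has the structure `CCOC(=O)c1c(F)c(N)c2c(=O)cc(-c3ccc(N)c(F)c3)oc2c1F`. The change from compound 3 is ethoxycarbonyl in place of chloro on an aromatic carbon. All three measured steps touch this same aromatic carbon: hydrogen there gives the strongest inhibition, chloro a modest loss, and hydroxy a loss beyond the measurable range. Ethoxycarbonyl brings the largest group yet to this position, so a further weakening is expected, of a size between the modest chloro step and the large hydroxy step. The expected step is a 7.1-fold higher number from compound 3 to compound 4 (0.85 log units; beyond the scatter). Compound 4 is therefore estimated at 1500 nM, with a range from 300 nM to 10000 nM.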

Compound 4, half-maximal inhibitory concentration: 1400 nM
The estimate for compound 4 lay 1.1-fold (0.03 log units) above the measured number; low and high end bracket the measured number.
By their numbers in this assay, from the lowest: compound 1; then compound 3; then compound 4. At a limit, above all of these: compound 2.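

In this assay, this aromatic carbon accepts a far larger group at only a modest cost: ethoxycarbonyl, with 5 heavy atoms, replaces chloro, with 1, in a 6.7-fold higher number from compound 3 to compound 4 (0.82 log units; beyond the scatter), although measured against hydrogen the change is large, at a 35-fold higher number from compound 1 to compound 4 (1.54 log units; beyond the scatter). The step from hydroxy is an at least 7.1-fold lower number from compound 2 to compound 4 (0.85 log units; beyond the scatter), so the group with the most heavy atoms among those shown does not give the weakest inhibition here, and compound 2 goes against any simple order by group size. Compound 2 is held at a limit, so that step is a bound and not an exact size: the limit of > 10000 nM in this assay, at which 1 of the 4 values shown sits.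

The compounds shown leave open whether a carboxylic acid or an amide on this carbon would behave more like ethoxycarbonyl or more like hydroxy, which would help show which part of the ethoxycarbonyl group the result depends on. They also leave open whether a methyl group, a methoxy group or an amine here could match hydrogen or give a lower number in this assay.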